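The source may hold more compounds than are shown below. What is called first, only, known or untested is meant among the compounds shown, and "the series" means these compounds.

Measured so far:

Compound 1 `COc1cc(OC)cc(-c2cn(-c3ccc(Oc4ccccc4)cc3)nn2)c1` — in a functional assay on MDA-MB-231 cells (Homo sapiens) for cytotoxicity, read by MTT assay (on this read-out higher numbers stand for weaker inhibition and lower numbers for stronger inhibition), compound 1 gives > 10000 nM, a limit of the assay and not a number.

Compound 2 `Oc1cc(O)cc(-c2cn(-c3ccc(OC(F)(F)F)cc3)nn2)c1` — in this assay compound 2 gives > 10000 nM, likewise a limit.

Compound 3 `COc1cc(OC)cc(-c2cn(-c3ccc(OC(F)(F)F)cc3)nn2)c1` — in this assay compound 3 gives > 1000 nM, also a limit.

None of the three readings is a number, so the step from compound 3 to compound 1, (phenyl in place of trifluoromethyl on an oxygen on an aromatic ring), comes out as a step that the two limits leave unreadable from compound 3 to compound 1. The cores of compound 2 and compound 3 differ in more than one place, and that difference is not broken down here.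

Compound 4 `Oc1cc(O)cc(-c2cn(-c3ccc(Oc4ccccc4)cc3)nn2)c1` has not yet been measured. It stands to compound 2 as compound 1 stands to compound 3: phenyl in place of trifluoromethyl on an oxygen on an aromatic ring. The same change is already seen once, from compound 3 to compound 1, and there it could not be read. In this assay the step from compound 2 to compound 4 is expected to be a step that the limit leaves unreadable from compound 2 to compound 4. That expectation rests on compound 2, whose reading is only the limit (the limit of > 10000 nM in this assay, at which 2 of the 3 values shown sit), and on the unreadable step that the two limits leave unreadable from compound 3 to compound 1 from compound 3 to compound 1. Compound 4 is therefore estimated at 30000 nM, with a range from 8000 nM to 100000 nM, and most likely the assay will again report only a limit.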

Compound 4, half-maximal inhibitory concentration: > 10000 nM
Compound 4: a limit, no number; the forecaster's own chance of this, stated with the estimate: 85%; the middle value is on the limit's open side.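

In this assay compound 4 gives > 10000 nM, a limit and not a number. Compound 2 also stands only at a limit, so no step can be read between compound 2 and compound 4. The compounds shown leave open whether phenyl in place of trifluoromethyl changes the read-out at all, and none of the four has a numerical value.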